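From a Methylated Amide to a Methyl Carbamate

The source may report more compounds than this note shows. Statements on the series, on what has been measured and on what is new or still open speak of the compounds shown alone.

In a functional assay on the whole organism for agonist activity, with Mus musculus as the target (on this read-out lower numbers stand for an effect already at smaller amounts and higher numbers for an effect only at larger amounts of compound), compound 1 `CC(=O)NCC#CCn1cncc1C` gives 66 mg/kg. Compound 2 `CC(=O)N(C)CC#CCn1cncc1C` reads > 100 mg/kg, which is a limit of the assay and not a number. Compound 3 `COC(=O)NCC#CCn1cncc1C` differs from compound 2 as follows: (methoxycarbonyl)amino in place of acetyl(methyl)amino on a saturated chain carbon bound to a triple-bonded carbon, with (methoxycarbonyl)amino in place of acetyl(methyl)amino on a saturated chain carbon bound to a triple-bonded carbon. Going by the values given here, only one measured step bears on this change, the methyl in place of hydrogen on an amide-type nitrogen, an at least 1.5-fold higher number from compound 1 to compound 2 (0.18 log units; that floor lies within the scatter). Among the compounds with values here, compound 3 has that hydrogen again, so a move towards a lower number is expected in this assay, though only weakly, as the swap of acetyl for methoxycarbonyl has no measured counterpart. The expected step is an at least 1.4-fold lower number from compound 2 to compound 3 (0.15 log units; that floor lies within the scatter). Compound 3 is estimated at 70 mg/kg, within an expected range of 25 mg/kg to 150 mg/kg.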

Compound 3, dose for half-maximal effect: > 100 mg/kg
Compound 3: a limit, no number; the forecaster's own chance of this, stated with the estimate: 35%; middle value at least 1.4-fold (0.15 log units) away from the limit.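

Compound 3 carries the hydrogen on nitrogen that compound 2 lacks, yet in this assay compound 3 reads > 100 mg/kg, a limit of the assay and not a number. So the presence of that hydrogen alone does not bring a measurable value when methoxy stands in place of methyl on the carbonyl carbon, a change that gives an at least 1.5-fold higher number from compound 1 to compound 3 (0.18 log units; that floor lies within the scatter). The step between the methylated amide and the methyl carbamate cannot be read because both compounds end at a limit: the limit of > 100 mg/kg in this assay, at which 2 of the 3 values shown sit.

Going by these compounds, how far compound 2 and compound 3 lie beyond that limit remains open, as does the true size of the step from the acetamide. Also open, on these data alone, is whether a urea or an ethyl carbamate at this place on the chain would give a number in this assay.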